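Cinnamyl-piperidine carboxamides: anilide to pyridin-2-yl amide

The source may hold more compounds than are shown below. What is called first, only, known or untested is meant among the compounds shown, and "the series" means these compounds.

Measured so far:
compound 1, `CCCCc1ccc(NC(=O)C2CCN(C/C=C/c3ccccc3)CC2)cc1`, 5910 nM
compound 2, `COc1ccc(NC(=O)C2CCN(C/C=C/c3ccccc3)CC2)cc1`, 83800 nM

Both compounds share the cinnamyl-piperidine carboxamide core and differ only in the group on the aromatic carbon of the amide-bound ring. Among the compounds with values here, in a functional assay on A549 cells (Homo sapiens) for inhibition, read by MTT assay, with a stated time of 72 h (on this read-out lower numbers stand for stronger inhibition and higher numbers for weaker inhibition), compound 2 gives the higher of the two numbers, and the single step within the set, a 14-fold higher number from compound 1 to compound 2 (1.15 log units; beyond the scatter), is large and well beyond the scatter; compound 1 stands as the nearer and lower point.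

Compound 3, `O=C(Nc1ccccn1)C1CCN(C/C=C/c2ccccc2)CC1`, is the next compound to be measured. Relative to compound 2 the change is pyridin-2-yl in place of 4-methoxyphenyl on an amide-type nitrogen. Within the data shown here, the one step seen so far concerns a substituent on the same amide-bound ring, not the ring itself, so it bears on the new change only by showing that this part of the molecule moves the read-out strongly. Among the measured compounds shown here, no measured pair tells which way a swap of the whole ring goes. Given that compound 2 holds the weakest number and that the amide-bound ring has already shown a large swing, a step back toward lower numbers is expected, a 2.8-fold lower number from compound 2 to compound 3 (0.45 log units; beyond the scatter), though with wide uncertainty. For compound 3 the estimate is 30000 nM, within 8000 nM to 120000 nM.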

Compound 3, half-maximal inhibitory concentration: 89300 nM
For compound 3 the middle estimate is 3.0-fold (0.47 log units) below the measured one; low and high end bracket the measured number.
By their numbers in this assay, from the lowest: compound 1; then compounds 2 and 3 (each within the scatter of the next).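

In this assay the exchange of the whole 4-methoxyphenyl ring for pyridin-2-yl on the amide-type nitrogen gives a 1.1-fold higher number from compound 2 to compound 3 (0.03 log units; within the scatter) and so leaves the read-out unmoved within the scatter. Compound 2 and compound 3 therefore stand level, although the ring of carbon only gives way to a ring with a hetero atom and the methoxy group is gone. This part of the molecule, which answered strongly to butyl against methoxy with a 14-fold higher number from compound 1 to compound 2 (1.15 log units; beyond the scatter), does not answer to this ring swap, so a large swing here does not follow from every change at this place, and no measurement on hand offers an explanation for the level result.

Still open, going by these compounds, is whether a butyl group on the pyridin-2-yl ring would bring the number down towards that of compound 1, which would show whether the butyl group alone carries the difference. Also open, on these data alone, is how the read-out responds to a chain longer than butyl, such as hexyl, or to an amine or a carboxylic acid on the amide-bound ring.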